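Shortening a Long Chain: Expected Effect on Cell Toxicity

The compounds below may be only part of what the source reports. "The series", "measured", "known", "first", "only" and "open" are said of these compounds alone.

Measured compounds:
compound 1 `CCCCCCCCCCc1cc2cn(COCCO)c(O)nc-2n1` — 80000 nM
compound 2 `CCCCCCCCCCCc1cc2cn(COCCO)c(O)nc-2n1` — 80000 nM

In a functional assay on HEL cells (Homo sapiens), read by microscopy (on this read-out higher numbers stand for lower toxicity in this test and lower numbers for higher toxicity in this test), compound 1 gives 80000 nM and compound 2 gives 80000 nM. Among the compounds with values here, the only measured step, no change at the digits printed from compound 1 to compound 2 (within the scatter), adds one carbon far out on the chain and leaves the read-out unchanged within the scatter. On these numbers compound 2 stands level with compound 1.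

Compound 3 `CCCCc1cc2cn(COCCO)c(O)nc-2n1` is the next compound. Its difference from compound 2 is hydrogen in place of heptyl on a saturated chain carbon, four bonds along the chain from an aromatic carbon. Within the data shown here, the measured step concerns a small addition at the far end of the chain; the change here removes a much larger piece, so no measured step bears on it directly, and only a loose expectation is possible. Compound 3 is expected to give 80000 nM, with a range from 20000 nM to 320000 nM. That expectation corresponds to a step of no change at the digits printed from compound 2 to compound 3 (within the scatter).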

Compound 3, minimum cytotoxic concentration: > 400000 nM
Compound 3: only a limit was reported; the forecaster's own chance of this, stated with the estimate: 20%; middle value at least 5.0-fold (0.69 log units) from the limit.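

In this assay, hydrogen in place of heptyl on a saturated chain carbon, four bonds along the chain from an aromatic carbon, gives an at least 5.0-fold higher number from compound 2 to compound 3 (0.69 log units; beyond the scatter). Hydrogen in place of hexyl at the same place gives an at least 5.0-fold higher number from compound 1 to compound 3 (0.69 log units; beyond the scatter), so a large cut in the chain moves this read-out towards lower toxicity, which the one-carbon step among the longest chains did not show. The value for compound 3 is a limit of the assay and not a number, so the true size of both steps stays unknown: the limit of > 400000 nM in this assay, at which 1 of the 3 values shown sits.

The compounds shown leave open how an octyl chain at this place would read, and so at what chain length the read-out begins to move. They also leave open how the read-out would respond to an amine at the far end of the chain.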